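Compound 4: will a methyl rescue growth inhibition?

The source may hold more compounds than are shown below. What is called first, only, known or untested is meant among the compounds shown, and "the series" means these compounds.

Measured in a functional assay on U-251 cells (Homo sapiens) for cytotoxicity; on this read-out higher numbers stand for weaker inhibition of growth and lower numbers for stronger inhibition of growth:
- compound 1 `CSc1ccc(C2=C(c3ccc(F)c(F)c3)C(=O)N3CCCC3C2)cc1`: 15000 nM
- compound 2 `CSc1ccc(C2=C(c3ccc(O)c(O)c3)C(=O)N3CCCC3C2)cc1`: 30000 nM
- compound 3 `CSc1ccc(C2=C(c3ccc(O)cc3)C(=O)N3CCCC3C2)cc1`: > 100000 nM

Compound 3 gives > 100000 nM, which is a limit and not a number. The next compound, compound 4 `CSc1ccc(C2=C(c3ccc(C)cc3)C(=O)N3CCCC3C2)cc1`, differs from it by methyl in place of hydroxy on an aromatic carbon, so that 4-hydroxyphenyl becomes 4-methylphenyl.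

Going by the values given here, no measured step makes this exact change, so the nearest ones must serve as a guide. Two steps end at compound 3, and both lie beyond the scatter. The first is an at least 6.6-fold higher number from compound 1 to compound 3 (0.82 log units; beyond the scatter). The second is an at least 3.3-fold higher number from compound 2 to compound 3 (0.52 log units; beyond the scatter). Replacing that single hydroxy with another group could therefore move the number down, towards compound 1 and compound 2. Hydroxy alone does not set the outcome, however: compound 2 carries two hydroxy groups and still gives 30000 nM, and the step of a 2.0-fold higher number from compound 1 to compound 2 (0.30 log units; within the scatter) stays within the scatter.

A step in this assay towards a lower number, meaning stronger inhibition of growth, is expected, though its size is uncertain and a second limit remains possible. The expected step is an at least 2.5-fold lower number from compound 3 to compound 4 (0.39 log units; beyond the scatter). For compound 4 the estimated value is 40000 nM, with an expected range from 12000 nM to 100000 nM.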

Compound 4, concentration for 50% growth inhibition: 400 nM
Compound 4: the middle estimate sits 100-fold (2.00 log units) above what was measured; measured number below the stated range.
By their numbers in this assay, from the lowest: compound 4; then compounds 1 and 2 (each within the scatter of the next). At a limit, above all of these: compound 3.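

In this assay, going by these compounds alone, the position para to a large group proves far more decisive than the earlier compounds could show: a change of one heavy atom there, methyl in place of hydroxy, gives an at least 250-fold lower number from compound 3 to compound 4 (2.39 log units; beyond the scatter) on this read-out. Compound 3 carries a limit and not a number, so the true size of that step cannot be read, only its smallest possible size: the limit of > 100000 nM in this assay, at which 1 of the 4 values shown sits. Swapping the whole substituted phenyl group tells the same story, with a 75-fold lower number from compound 2 to compound 4 (1.88 log units; beyond the scatter) and a 38-fold lower number from compound 1 to compound 4 (1.57 log units; beyond the scatter) in these changes, although compound 1 and compound 2 lie within the scatter of each other.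

The compounds shown leave open whether growth inhibition depends on methyl itself or on the loss of hydroxy, a question that a plain phenyl group, with hydrogen at this position, would help to settle. As far as these compounds go, it also remains open whether a longer chain such as ethyl, or a methoxy group or an amine at the same place, would keep this strong inhibition of growth or lose it.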